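Acyclic side chain series: step from hydroxy to dimethylamino

The compounds below may be only part of what the source reports. "The series", "measured", "known", "first", "only" and "open" are said of these compounds alone.

Measured compounds, each in a functional assay on L1210 cells (Mus musculus) for inhibition; a lower number here means a stronger inhibitor, a higher number a weaker inhibitor:
compound 1 `O=c1ccn(COCCO)c(=O)[nH]1`, a limit of > 1000 ug/mL
compound 2 `Cc1cn(COCCO)c(=O)[nH]c1=O`, a limit of > 1000 ug/mL
compound 3 `OCCOCn1cnc2c(O)ncnc21`, a limit of > 1000 ug/mL

Every value in this assay is a limit and not a number, so compound 3 cannot be placed against compound 1 or compound 2; the three share (the limit of > 1000 ug/mL in this assay, at which 3 of the 3 values shown sit). For the measured compounds named here, the only single-point step among the measured compounds, a step that the two limits leave unreadable from compound 1 to compound 2, is one that the two limits leave unreadable, methyl in place of hydrogen on an aromatic carbon.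

Compound 4 `CN(C)c1ncnc2c1ncn2COCCO` differs from compound 3 by dimethylamino in place of hydroxy on an aromatic carbon. Going by the values given here, no measured step bears on this change: the step from compound 1 to compound 2 concerns a different group on a different core, and its size is not readable either. Nothing in the series indicates a direction for this assay. The expectation is therefore set by the common limit, with the estimated step of a number no higher from compound 3 to compound 4 (the limit leaves the size open) as a placeholder about which nothing is known. Compound 4 is expected to give about 1000 ug/mL in this assay, in a range from 200 ug/mL to 3000 ug/mL, and most likely again only a limit.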

Compound 4, concentration for 50% inhibition: > 500 ug/mL
Compound 4 ended at the assay's limit; the forecaster's own chance of this, stated with the estimate: 75%; the middle value does not contradict the limit.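

In this assay compound 3 gives > 1000 ug/mL, which is a limit and not a number. Compound 4 gives > 500 ug/mL, also a limit. The step between compound 3 and compound 4 therefore cannot be read. The compounds shown leave open whether dimethylamino in place of hydroxy on this aromatic carbon changes inhibition in this assay at all, and in which direction.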